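Dichlorophenyl Analogue in the Maximal Electroshock Series

The source may report more compounds than this note shows. Statements on the series, on what has been measured and on what is new or still open speak of the compounds shown alone.

Measured so far:
compound 1, `CC1(c2ccccc2)CC(=O)N(CC(=O)N2CCN(c3cccc(C(F)(F)F)c3)CC2)C1=O` — 300 mg/kg
compound 2, `COc1cccc(N2CCN(C(=O)CN3C(=O)CC(C)(c4ccccc4)C3=O)CC2)c1` — "not active" (no number reported)

Two compounds share the imide core and the piperazine amide linker and differ only in the aryl ring on the amine nitrogen in a ring. In a functional assay on the whole organism (strain CD-1) with Mus musculus as the target, in the maximal electroshock model, with a stated time of 0.5 h (a lower number here means that less compound is needed, a higher number that more compound is needed for the effect), compound 1 gives 300 mg/kg. In this assay compound 2 gives "not active" (no number reported), so no single number stands for compound 2; it sits at the inactive end of the series and cannot be placed on the scale.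

Compound 3, `CC1(c2ccccc2)CC(=O)N(CC(=O)N2CCN(c3ccc(Cl)c(Cl)c3)CC2)C1=O`, is the next analogue. It differs from compound 2 by 3,4-dichlorophenyl in place of 3-methoxyphenyl on an amine nitrogen in a ring. Within the data shown here, no measured step covers this exchange, so the expected size rests only on the two measured values: compound 1 carries a different aryl ring and is active, compound 2 is not. For compound 3 the expectation is a move from no effect to a measurable minimum effective dose, of a size comparable to that of compound 1, with a real chance that no number is obtained.

Compound 3 is expected to give 300 mg/kg in this assay, within 100 mg/kg to 1000 mg/kg.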

Compound 3, minimum effective dose: "not active" (no number reported)
Compound 3: no number reported, so the estimate cannot be set against anything.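

Compound 2 and compound 3 both lack a number in this assay so no step can be read between them. The compounds shown leave open how 3-methoxyphenyl and 3,4-dichlorophenyl would rank against each other on a dose scale. Nothing available here offers an explanation for the result in compound 3.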